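Compound 3 to compound 4: 3-hydroxypropyl for cyano

The source may hold more compounds than are shown below. What is called first, only, known or untested is meant among the compounds shown, and "the series" means these compounds.

In an ADME assay on microsomes from liver (Rattus norvegicus) for metabolic stability, with a stated time of 10 min (a higher number here means that more of the compound is left, a lower number that less of the compound is left), compound 3 (`N#Cc1cc(-c2ccccc2C(F)(F)F)cc2nc(C3=NOC4(CCCCC4)C3)[nH]c12`) gives 96% within the scatter of compound 2 (`Fc1cc(-c2ccccc2C(F)(F)F)cc2nc(C3=NOC4(CCCCC4)C3)[nH]c12`) at 100% and clear of compound 1 (`FC(F)(F)c1ccccc1-c1ccc2[nH]c(C3=NOC4(CCCCC4)C3)nc2c1`) at 75% on the lower side. Compound 4 (`OCCCc1cc(-c2ccccc2C(F)(F)F)cc2nc(C3=NOC4(CCCCC4)C3)[nH]c12`) carries 3-hydroxypropyl in place of cyano on an aromatic carbon. Among the compounds with values here, three measured steps bear on this: fluoro for hydrogen (a number 25 percentage points higher from compound 1 to compound 2 (beyond the scatter)), cyano for hydrogen (a number 21 percentage points higher from compound 1 to compound 3 (beyond the scatter)) and cyano for fluoro (a number 4 percentage points lower from compound 2 to compound 3 (within the scatter)). Within the data shown here, no measured compound carries a chain here, so these steps guide the change only loosely. A modest fall of about the size of the cyano gain, taken in reverse, is expected in this assay with wide uncertainty. The expected step is a number 16 percentage points lower from compound 3 to compound 4 (beyond the scatter) on this estimate. The value estimated for compound 4 is 80% within an expected range of 55% to 98% in this assay.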

Compound 4, percent of the compound remaining: 74%
Estimate against measurement, compound 4: 6 percentage points above; the measured number falls inside the stated range.
By their numbers in this assay, from the lowest: compounds 4 and 1 (each within the scatter of the next); then compounds 3 and 2 (each within the scatter of the next).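

In this assay, the rise seen with fluoro and cyano at this position does not extend to a chain: 3-hydroxypropyl in place of hydrogen gives a number 1 percentage points lower from compound 1 to compound 4 (within the scatter) and so keeps none of that rise. Against the two earlier groups the chain loses ground, with a number 22 percentage points lower from compound 3 to compound 4 (beyond the scatter) and a number 26 percentage points lower from compound 2 to compound 4 (beyond the scatter). No measurement at hand accounts for this loss.

On these data alone, whether the loss follows the chain length or the terminal hydroxyl stays open. A plain propyl chain, a hydroxymethyl group or a chain ending in an amine or a carboxylic acid would separate the two.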